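Anilide in place of dihydroxypropyl amide: an oral exposure question

The compounds below may be only part of what the source reports. "The series", "measured", "known", "first", "only" and "open" are said of these compounds alone.

Compound 3 `NCc1cc(Oc2cccc(C(=O)NC[C@@H](O)CO)c2)nc(C(F)(F)F)c1` stands second highest of the three compounds measured in an ADME assay on the whole organism (lung, Mus musculus) for pharmacokinetics, read by LC-MS, at a dose of 30 mg/kg by the oral route (a higher number here means more compound in the circulation at the dose given, a lower number less compound in the circulation), where compound 3 gives 1920 nM. Its closest neighbour is compound 1 `NCc1cc(Oc2cccc(C(=O)N3CC[C@@H](N)C3)c2)nc(C(F)(F)F)c1`, which in this assay gives 1230 nM, a gap within the scatter. The furthest is compound 2 `CONC(=O)c1cccc(Oc2cc(CN)cc(C(F)(F)F)n2)c1`, which in this assay gives 8780 nM; the step of a 4.6-fold lower number from compound 2 to compound 3 (0.66 log units; beyond the scatter) is beyond the scatter.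

Compound 4 `NCc1cc(Oc2cccc(C(=O)Nc3ccccc3)c2)nc(C(F)(F)F)c1` differs from compound 3 in one place: phenyl in place of 2,3-dihydroxypropyl on an amide-type nitrogen. Among the measured compounds shown here, no measured step introduces an aromatic ring on this amide-type nitrogen, so the bearing of the measured steps is indirect. The step of a 7.1-fold higher number from compound 1 to compound 2 (0.85 log units; beyond the scatter) and the step of a 4.6-fold lower number from compound 2 to compound 3 (0.66 log units; beyond the scatter) both show that what sits on the carbonyl carbon can move the number by a modest amount in either direction, while the step of a 1.6-fold higher number from compound 1 to compound 3 (0.19 log units; within the scatter) stayed within the scatter. On this basis a step of a 1.3-fold higher number from compound 3 to compound 4 (0.11 log units; within the scatter) is expected, with wide uncertainty. Compound 4 is estimated to give 2500 nM in this assay, with a range from 700 nM to 9000 nM.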

Compound 4, maximal plasma concentration: 10300 nM
Compound 4: middle estimate off by 4.1-fold (0.61 log units), on the low side; the measured number lies above the stated range.
By their numbers in this assay, from the lowest: compounds 1 and 3 (each within the scatter of the next); then compounds 2 and 4 (each within the scatter of the next).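

In this assay, the high number of compound 2 proves not to be particular to methoxy on the amide-type nitrogen: phenyl in that place gives a result within the scatter of it (a 1.2-fold higher number from compound 2 to compound 4 (0.07 log units; within the scatter)). Against the other two amides the same change is a clear one, both for phenyl in place of 2,3-dihydroxypropyl (a 5.4-fold higher number from compound 3 to compound 4 (0.73 log units; beyond the scatter)) and for anilino in place of 3-aminopyrrolidin-1-yl on the carbonyl carbon (an 8.4-fold higher number from compound 1 to compound 4 (0.92 log units; beyond the scatter)). So this position, which had shown a single high compound, now holds two quite different groups at that level, one with an aromatic ring and one without.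

Going by these compounds, whether a phenyl ring carrying a carboxylic acid or an amine, or a cyclohexyl group, would hold the number on this nitrogen stays open. Nothing available explains why phenyl and methoxy land together here.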